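A few compounds are considered here, and "the series" means these few. Any claim that something is new, unique, unknown or untested is made for them only; others in the source may bear on it.

Going by the values given here, in a functional assay on DU-145 cells (Homo sapiens) for inhibition, read by trypan blue exclusion, with a stated time of 72 h (a higher number here means a weaker inhibitor, a lower number a stronger inhibitor), compound 1 `Cn1c(=O)c(S(=O)(=O)c2ccc(Cl)cc2Cl)cc2cnc(Nc3ccc4[nH]ccc4c3)nc21` gives 1000 nM, the lowest number measured so far, which makes it the stronger inhibitor of the measured pair. Its sulfonyl analogue, compound 2 `Cn1c(=O)c(S(=O)(=O)c2ccc(C(=O)O)cc2)cc2cnc(Nc3ccc4[nH]ccc4c3)nc21`, gives 10000 nM. Compound 3 `Cn1c(=O)c(C(=O)Nc2ccc(F)cc2F)cc2cnc(Nc3ccc4[nH]ccc4c3)nc21` has not yet been measured. It differs from compound 1 at one place on the shared core, where (2,4-difluorophenyl)carbamoyl stands in place of (2,4-dichlorophenyl)sulfonyl: (2,4-difluorophenyl)carbamoyl in place of (2,4-dichlorophenyl)sulfonyl on an aromatic carbon.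

Among the compounds with values here, only one measured step bears on this change. That is a 10-fold higher number from compound 1 to compound 2 (1.00 log units; beyond the scatter), in which 4-carboxyphenyl replaced 2,4-dichlorophenyl on the sulfonyl sulfur. It is an indirect guide, since the sulfonyl stays in compound 2 but is gone from compound 3. It does show that the number can move when the group at this place changes. Compound 3 has no carboxyl group and keeps a halogen-bearing phenyl ring, so it resembles compound 1 more closely than compound 2 does. The expected change is therefore small, with more room towards weaker inhibition than towards stronger. The expected size is a 1.5-fold higher number from compound 1 to compound 3 (0.18 log units; within the scatter), which is no clear shift beyond the scatter. For compound 3 the estimated value is 1500 nM, with an expected range of 300 nM to 7000 nM.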

Compound 3, half-maximal inhibitory concentration: 5000 nM
Estimate against measurement, compound 3: 3.3-fold (0.52 log units) below; measured number inside the range.
By their numbers in this assay, from the lowest: compound 1; then compounds 3 and 2 (each within the scatter of the next).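

Replacing (2,4-dichlorophenyl)sulfonyl with (2,4-difluorophenyl)carbamoyl in this assay gives a 5.0-fold higher number from compound 1 to compound 3 (0.70 log units; beyond the scatter) and so the number at this position moves even when no carboxyl group enters and a halogen-bearing phenyl ring stays. The earlier step changed only the ring on a sulfonyl, whereas this one changes the link to the core as well as the halogens on the ring: a sulfonyl with no hydrogen-bond donor gives way to a carbamoyl with one, and chlorine gives way to fluorine, so this single step cannot tell these changes apart. Compound 3 at 5000 nM and compound 2 at 10000 nM lie within the scatter of each other, which leaves compound 1 alone at the low end of these numbers.

No measurement shown here explains the rise in the number. Still open, from the compounds shown here alone, is how a (2,4-dichlorophenyl)carbamoyl or a (2,4-difluorophenyl)sulfonyl group would read, since either would separate the link from the halogens, and how an amine or a longer chain on this aromatic carbon would compare.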